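Swapping Butylamino for Propoxy on a Shared Core

A few compounds are considered here, and "the series" means these few. Any claim that something is new, unique, unknown or untested is made for them only; others in the source may bear on it.

Compound 2 `CCCCNc1nc(N)c2nc(O)n(Cc3ccccc3)c2n1` gives 1 uM in a functional assay (spleen, spleen) for activation, with Mus musculus as the target (a higher number here means that more compound is needed for the effect, a lower number that less compound is needed), the highest of the two numbers measured. Compound 1 `CCCCc1nc(N)c2nc(O)n(Cc3ccccc3)c2n1` gives 0.03 uM. Compound 3 `Nc1ncnc2c1nc(Cl)n2Cc1ccccc1` gives only a limit of the assay, > 10 uM, so no number is known for it. Going by the values given here, the single measured step, a 33-fold higher number from compound 1 to compound 2 (1.52 log units; beyond the scatter), shows that introducing the butylamino group raised the number steeply. Compound 4 `CCCOc1nc(N)c2nc(O)n(Cc3ccccc3)c2n1` differs from compound 2 as follows: propoxy in place of butylamino on an aromatic carbon. Among the compounds with values here, no measured step covers an alkoxy group, so the expectation rests on compound 1 and compound 2 alone, with the propoxy group carrying no hydrogen-bond donor. Compound 4 is expected to land between the two, a step estimated as a 10-fold lower number from compound 2 to compound 4 (1.00 log units; beyond the scatter). Compound 4 is therefore estimated at 0.1 uM, within a range from 0.03 uM to 0.4 uM.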

Compound 4, minimum effective concentration: 0.01 uM
For compound 4 the middle estimate is 10-fold (1.00 log units) above the measured one; the whole stated range lies above it.
By their numbers in this assay, from the lowest: compound 4; then compound 1; then compound 2. At a limit, above all of these: compound 3.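

At this position, between two ring nitrogen atoms, propoxy in place of butylamino gives a 100-fold lower number from compound 2 to compound 4 (2.00 log units; beyond the scatter) in this assay, so the steep rise seen with butylamino does not carry over to a chain joined through oxygen. Against the butyl chain, propoxy gives a 3.0-fold lower number from compound 1 to compound 4 (0.48 log units; beyond the scatter), so the oxygen-joined chain also needs less compound than the one joined through carbon. Nothing measured here accounts for these steps.

Still open, going by these compounds, is how propylamino would compare with propoxy, which would separate the linking atom from chain length. Open too, on these data alone, is how ethoxy or butoxy would fare.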